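Acetamido in Place of Isobutoxy: a Cytotoxicity Estimate

The compounds below may be only part of what the source reports. "The series", "measured", "known", "first", "only" and "open" are said of these compounds alone.

Of the compounds shown here, three sharing one core have been tested in an ADME assay on HepG2 cells (Homo sapiens) for cytotoxicity, read by luminescence, with a stated time of 72 h; a higher number here means that more compound is needed for the effect, a lower number that less compound is needed. Compound 1 `CCOC(=O)c1c(-c2cccc(OC)c2)[nH]c2cc(OC)ccc2c1=O` carries a methoxy group on the pendant ring. In this assay compound 1 gives only a limit, > 21500 nM. Compound 2 `CCOC(=O)c1c(-c2cccc(OCC(C)C)c2)[nH]c2cc(OC)ccc2c1=O` carries an isobutoxy group in its place; in this assay compound 2 likewise gives only a limit, > 21500 nM. Compound 3 `CCOC(=O)c1c(-c2cccc(OCc3ccccc3)c2)[nH]c2cc(OC)ccc2c1=O` carries a benzyloxy group; in this assay compound 3 also stops at a limit, > 21500 nM. Because all three sit at the limit of > 21500 nM in this assay, at which 3 of the 3 values shown sit, the steps a step that the two limits leave unreadable from compound 1 to compound 2, a step that the two limits leave unreadable from compound 1 to compound 3 and a step that the two limits leave unreadable from compound 2 to compound 3 cannot be sized. Compound 2 therefore stands where every other compound stands: at the limit, with no number to compare.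

Compound 4 `CCOC(=O)c1c(-c2cccc(NC(C)=O)c2)[nH]c2cc(OC)ccc2c1=O` is unmeasured. It differs from compound 2 as follows: acetamido in place of isobutoxy on an aromatic carbon. Within the data shown here, none of the measured steps carries a readable size, and none of them involves an acetamido group, so they offer no direction for the expected step that the limit leaves unreadable from compound 2 to compound 4. The expectation is that compound 4 will again fall at or near the limit, estimated at 30000 nM, within 10000 nM to 100000 nM, and most likely reported only as a limit.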

Compound 4, half-maximal effective concentration: > 21500 nM
Compound 4 ended at the assay's limit; the forecaster's own chance of this, stated with the estimate: 80%; the middle value does not contradict the limit.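

No step from compound 1, compound 2 or compound 3 to compound 4 can be read in this assay, because all four compounds stop at the same limit: the limit of > 21500 nM in this assay, at which 4 of the 4 values shown sit.

The compounds shown leave open where the true value of each one lies, and whether any of these group changes alters the result in this test at all.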